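Notes on the aryl swap at the saturated ring carbon

A few compounds are considered here, and "the series" means these few. Any claim that something is new, unique, unknown or untested is made for them only; others in the source may bear on it.

In a functional assay on the whole organism (strain Wistar) for inhibition, with Rattus norvegicus as the target, read by paw edema, with stated times of 30 min and 5 h, at a dose of 20 mg/kg by the oral route (on this read-out lower numbers stand for less inhibition and higher numbers for more inhibition at the one dose given (going by the name of the read-out)), compound 3 `Cc1cc(O)c(C2=NN(c3ccc(S(N)(=O)=O)cc3)C(c3ccc(Cl)cc3)C2)cc1Cl` gives 71.4%. Compound 2 `Cc1cc(O)c(C2=NN(c3ccc(S(N)(=O)=O)cc3)C(c3ccccc3Cl)C2)cc1Cl` gives 71.4%, and no change at the digits printed from compound 2 to compound 3 (within the scatter), so compound 3 stands level with compound 2, the two together the highest of the three numbers. Compound 1 `Cc1cc(O)c(C2=NN(c3ccc(S(N)(=O)=O)cc3)C(c3ccccc3O)C2)cc1Cl` gives 59.5%, and a number 11.9 percentage points higher from compound 1 to compound 3 (beyond the scatter); likewise a number 11.9 percentage points higher from compound 1 to compound 2 (beyond the scatter). Compound 4 `COc1ccc(C2CC(c3cc(Cl)c(C)cc3O)=NN2c2ccc(S(N)(=O)=O)cc2)cc1OC` differs from compound 3 by 3,4-dimethoxyphenyl in place of 4-chlorophenyl on a saturated ring carbon. Within the data shown here, no measured step covers this exact change; the steps at the same saturated ring carbon, a number 11.9 percentage points higher from compound 1 to compound 3 (beyond the scatter) and no change at the digits printed from compound 2 to compound 3 (within the scatter), show a modest rise when a hydroxy-bearing ring leaves and no change between two chlorophenyl rings. For compound 4 the step of a number 6.4 percentage points lower from compound 3 to compound 4 (within the scatter) is therefore expected to be small, at most a modest drop. Compound 4 is estimated at 65%, within 50% to 78%.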

Compound 4, a percentage reported as inhibition, in the whole organism at one dose (the size of the read-out at that dose, not a potency): 68.3%
Compound 4: middle estimate off by 3.3 percentage points, on the low side, within the range that was stated.
By their numbers in this assay, from the lowest: compounds 1, 4, 2 and 3 (each within the scatter of the next, the first and the last beyond it).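

At this saturated ring carbon this assay shows a number 3.1 percentage points lower from compound 3 to compound 4 (within the scatter) and a number 3.1 percentage points lower from compound 2 to compound 4 (within the scatter) on entry of 3,4-dimethoxyphenyl. The earlier compounds shown here held this level only with chlorophenyl rings, whereas compound 4 shows that a ring without chlorine can stand within the scatter of them. The same group also gives a number 8.8 percentage points higher from compound 1 to compound 4 (within the scatter) and so does not separate from the 2-hydroxyphenyl compound either.

Still open, as far as these compounds go, is whether an amine or a carboxylic acid on the aryl ring at this carbon would stay within this band. No evidence on the cause of these results is at hand.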